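Sulfonyl substituent and clearance: compound 2 to compound 3

A few compounds are considered here, and "the series" means these few. Any claim that something is new, unique, unknown or untested is made for them only; others in the source may bear on it.

Measured in an ADME assay on microsomes from liver (Homo sapiens) for pharmacokinetics, read by LC-MS, with a stated time of 60 min, tested at 1 uM; on this read-out lower numbers stand for slow clearance and higher numbers for fast clearance:
Compound 1 `O=C(NCc1ccc(S(=O)(=O)c2cccc(C(F)(F)F)c2)cc1)N1Cc2ccncc2C1`: 14 mL/min/kg
Compound 2 `O=C(NCc1ccc(S(=O)(=O)C2CCC(F)(F)CC2)cc1)N1Cc2ccncc2C1`: 6 mL/min/kg

Compound 2 holds the lower of the two numbers. Compound 3 `O=C(NCc1ccc(S(=O)(=O)C2CCN(C3COC3)CC2)cc1)N1Cc2ccncc2C1` carries 1-(oxetan-3-yl)piperidin-4-yl in place of 4,4-difluorocyclohexyl on a sulfonyl sulfur. Among the measured compounds shown here, the only measured step at this place is a 2.3-fold lower number from compound 1 to compound 2 (0.37 log units; beyond the scatter), modest and beyond the scatter, but it involves a different group. For the measured compounds named here, no measured compound carries the entering group, so the direction remains open, and no change beyond the scatter is expected in this assay. The expected step is a 1.2-fold higher number from compound 2 to compound 3 (0.07 log units; within the scatter). The estimate for compound 3 is 7 mL/min/kg, with an expected range of 4 mL/min/kg to 14 mL/min/kg.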

Compound 3, clearance: 10 mL/min/kg
Estimate against measurement, compound 3: 1.4-fold (0.15 log units) below; the range from low to high includes it.
By their numbers in this assay, from the lowest: compounds 2, 3 and 1 (each within the scatter of the next, the first and the last beyond it).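

At this sulfonyl sulfur, 1-(oxetan-3-yl)piperidin-4-yl is the only group shown with hetero atoms in its rings, and in this assay it gives a 1.7-fold higher number from compound 2 to compound 3 (0.22 log units; within the scatter) and, against 3-(trifluoromethyl)phenyl, a 1.4-fold lower number from compound 1 to compound 3 (0.15 log units; within the scatter). The entering group therefore cannot be ranked against either earlier group, although those two stand apart from each other. No available evidence explains these numbers. Open, going by these compounds, is whether the oxetan-3-yl part matters for the clearance number, which a 1-methylpiperidin-4-yl or tetrahydropyran-4-yl group on the same sulfur would help to settle.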